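Swapping the aryl hydrazone arm on a furoxan core

The compounds below may be only part of what the source reports. "The series", "measured", "known", "first", "only" and "open" are said of these compounds alone.

Compound 1, `Cc1c(C(=O)N/N=C/c2ccccn2)no[n+]1[O-]`, in an ADME assay on J774.1 cells (Mus musculus) for cytotoxicity, read by MTT assay, with a stated time of 48 h; on this read-out lower numbers stand for stronger inhibition and higher numbers for weaker inhibition: > 400000 nM
Compound 2, `Cc1c(/C=N/NC(=O)c2ccncc2)no[n+]1[O-]`, in this assay: > 400000 nM
Compound 3, `O=C(N/N=C/c1ccc2no[n+]([O-])c2c1)c1cccnc1`, in this assay: 31000 nM

The value for compound 1 in this assay is a limit of the assay and not a number. The same holds for compound 2, whose value in this assay is also a limit. Going by the values given here, compound 3 is the one compound here that gives a number in this assay, 31000 nM. Among the values shown, compound 1 therefore stands at the limit of > 400000 nM in this assay, at which 2 of the 3 values shown sit.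

Compound 4, `Cc1c(C(=O)N/N=C/c2ccco2)no[n+]1[O-]`, has not yet been measured. It differs from compound 1 by furan-2-yl in place of pyridin-2-yl on a carbon with a double bond to nitrogen. Among the compounds with values here, no measured pair in this set shows the effect of such a change, so the expected size of the step in this assay rests on the position of compound 1 alone. The account expects compound 4 to stay near the limit, with no step beyond the usual scatter, so that the step of a number no higher from compound 1 to compound 4 (the limit leaves the size open) is estimated as essentially flat. Compound 4 is accordingly estimated at 400000 nM, between 100000 nM and 1000000 nM.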

Compound 4, half-maximal inhibitory concentration: > 400000 nM
Compound 4: a limit, no number; the forecaster's own chance of this, stated with the estimate: 70%; the middle value lies on the limit itself.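

Going by these compounds alone, compound 4, like compound 1, gives a limit and not a number in this assay, so no step between the two can be read. The compounds shown leave open whether furan-2-yl in place of pyridin-2-yl on a carbon with a double bond to nitrogen changes the read-out at all.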